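The compounds below may be only part of what the source reports. "The series", "measured", "known", "first", "only" and "open" are said of these compounds alone.

Measured compounds:
Compound 1 `Cc1ccc(C2ON=C(c3ccccc3Cl)O2)cc1` — in an ADME assay on HEK293 cells (Homo sapiens) for cytotoxicity, read by MTT assay, with a stated time of 44 h (on this read-out higher numbers stand for weaker inhibition and lower numbers for stronger inhibition), compound 1 gives > 100000 nM, a limit of the assay.
Compound 2 `CCc1ccc(C2ON=C(c3ccccc3Cl)O2)cc1` — in this assay compound 2 gives > 100000 nM, also a limit.
Compound 3 `CC1(c2cccc(Br)c2)ON=C(c2cccc(Cl)c2)O1` — in this assay compound 3 gives > 100000 nM, again a limit.

All three values sit at the limit of > 100000 nM in this assay, at which 3 of the 3 values shown sit. The change methyl in place of hydrogen on a saturated chain carbon bound to an aromatic carbon gives a step that the two limits leave unreadable from compound 1 to compound 2. Compound 4 `CCC1(c2cccc(Br)c2)ON=C(c2cccc(Cl)c2)O1` carries the same kind of change on the core of compound 3, (methyl in place of hydrogen on a saturated chain carbon bound to a saturated ring carbon); here the place is a saturated chain carbon bound to a saturated ring carbon rather than one bound to an aromatic carbon. How the core of compound 3 differs from that of compound 1 is not broken down here. Within the data shown here, with every value so far a limit, the step in this assay is expected to be a step that the limit leaves unreadable from compound 3 to compound 4, resting on compound 3 at > 100000 nM. Compound 4 is estimated at 150000 nM.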

Compound 4, half-maximal inhibitory concentration: > 100000 nM
Compound 4 gave a limit, no number; the forecaster's own chance of this, stated with the estimate: 90%; the middle value is on the limit's open side.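

No step can be read from compound 3 to compound 4, since each gives only a limit of the assay: the limit of > 100000 nM in this assay, at which 4 of the 4 values shown sit.

The compounds shown leave open whether methyl in place of hydrogen alters the read-out at all in this assay, as none gives a number there.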